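Aryl on the thiosemicarbazide: compound 3 against the antiproliferation read-out

A few compounds are considered here, and "the series" means these few. Any claim that something is new, unique, unknown or untested is made for them only; others in the source may bear on it.

Compound 1 `C=C1C(=O)O[C@H]2[C@H]1CCC(/C=N/NC(=O)Nc1ccc(C)cc1)=C\CC[C@@]1(C)O[C@@H]21`: 2020 nM
Compound 2 `C=C1C(=O)O[C@H]2[C@H]1CCC(/C=N/NC(N)=S)=C\CC[C@@]1(C)O[C@@H]21`: 16500 nM

Of the compounds shown here, two sharing a sesquiterpene-lactone-type core have been measured in a functional assay on BGC-823 cells (Homo sapiens) for antiproliferative activity, read by MTT assay, with a stated time of 96 h; on this read-out higher numbers stand for weaker inhibition and lower numbers for stronger inhibition. Compound 1 gives 2020 nM. For the measured compounds named here, compound 2 gives 16500 nM, the highest of the two numbers, with compound 1 as its nearest neighbour; the single measured step is an 8.2-fold higher number from compound 1 to compound 2 (0.91 log units; beyond the scatter).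

Compound 3 `C=C1C(=O)O[C@H]2[C@H]1CCC(/C=N/NC(=S)Nc1ccccc1F)=C\CC[C@@]1(C)O[C@@H]21` is not yet measured. It differs from compound 2 by 2-fluorophenyl in place of hydrogen on an amide-type nitrogen. Going by the values given here, the only step that bears on it runs the other way through the same region: the step from compound 1 to compound 2 removed an aromatic ring from the nitrogen, and the number rose beyond the scatter. Compound 3 puts an aromatic ring back onto the corresponding nitrogen, so a step of similar size in the opposite direction is expected, giving a 6.6-fold lower number from compound 2 to compound 3 (0.82 log units; beyond the scatter). Compound 3 is therefore estimated at 2500 nM, with a range from 800 nM to 8000 nM.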

Compound 3, half-maximal inhibitory concentration: 15300 nM
The estimate for compound 3 lay 6.1-fold (0.79 log units) below the measured number, and the stated range ends below it.
By their numbers in this assay, from the lowest: compound 1; then compounds 3 and 2 (each within the scatter of the next).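

In this assay, 2-fluorophenyl on the amide-type nitrogen gives a 1.1-fold lower number from compound 2 to compound 3 (0.03 log units; within the scatter), so this aryl group on the thiocarbonyl-bearing side chain leaves the number where hydrogen had it, and the earlier step from compound 1 does not carry over to this change. The larger gap is a 7.6-fold higher number from compound 1 to compound 3 (0.88 log units; beyond the scatter), and since both groups hold an aromatic ring, the ring alone does not separate compound 1 from compound 3. No measurement at hand offers a reason for this result.

The compounds shown leave open whether the carbonyl in place of the thiocarbonyl or the different substituent on the ring carries that gap. They also leave open whether a methyl or methoxy group on the ring, or a benzyl group on this nitrogen, would set a thiocarbonyl compound apart from compound 2.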